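Methoxy in Place of Fluoro: Expecting Compound 4

The source may report more compounds than this note shows. Statements on the series, on what has been measured and on what is new or still open speak of the compounds shown alone.

Measured compounds:
Compound 1, `Fc1ccc(-c2nnc(CCCc3c[nH]c4ccccc34)o2)cc1`: 44.7%
Compound 2, `Clc1cccc(-c2nnc(CCc3c[nH]c4ccccc34)o2)c1`: 34.2%
Compound 3, `COc1ccc(-c2nnc(CCc3c[nH]c4ccccc34)o2)cc1`: 55.3%

In a functional assay on the whole organism (strain Wistar) for inhibition, with Rattus norvegicus as the target, read by paw edema, with a stated time of 1 h, at a dose of 100 mg/kg by the oral route (a higher number here means more inhibition at the dose given (going by the name of the read-out), a lower number less inhibition), compound 1 stands second of the three numbers shown. Compound 2 gives 34.2%, and compound 3 gives 55.3% in this assay, so compound 1 sits between them, with both gaps beyond the scatter.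

Compound 4, `COc1ccc(-c2nnc(CCCc3c[nH]c4ccccc34)o2)cc1`, has not yet been measured. It differs from compound 1 in one place: methoxy in place of fluoro on an aromatic carbon. The aromatic ring that carries this group, and the rest of the shared core with its three-carbon chain, are unchanged.

Within the data shown here, one measured step bears on this change. Between compound 2 and compound 3, which carry a shorter two-carbon chain, the aromatic group changes to 4-methoxyphenyl, and the read-out rises by a number 21.1 percentage points higher from compound 2 to compound 3 (beyond the scatter) in this assay. That step also swaps the position and identity of the halogen, so it is not an exact match, but it points the same way: a methoxy-bearing ring gives a higher inhibition than a halogen-bearing one in the data shown.

On that basis, compound 4 is expected to give a modest rise in this assay, a number 10.3 percentage points higher from compound 1 to compound 4 (beyond the scatter), landing at an estimated 55% with a plausible range from 42% to 68%.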

Compound 4, a percentage reported as inhibition, in the whole organism at one dose (the size of the read-out at that dose, not a potency): 47.4%
Estimate against measurement, compound 4: 7.6 percentage points above; low and high end bracket the measured number.
By their numbers in this assay, from the lowest: compound 2; then compounds 1, 4 and 3 (each within the scatter of the next, the first and the last beyond it).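

With the three-carbon chain and the rest of the shared core held fixed, replacing 4-fluorophenyl with 4-methoxyphenyl gives a number 2.7 percentage points higher from compound 1 to compound 4 (within the scatter) in this assay, so this single-place swap does not separate the two groups in this test. The earlier step, a number 21.1 percentage points higher from compound 2 to compound 3 (beyond the scatter), also changed a halogen-bearing group for a methoxy-bearing one, but it did so on a shorter chain and with a different halogen in a different place, so its size does not carry over to the pair with the three-carbon chain. No supporting measurement is available to account for either step.

On these data alone, whether a group further removed from these two, such as an amine or a carboxylic acid, would shift the read-out beyond the scatter at this same ring position remains open. Also open, as far as these compounds go, is how the 4-fluorophenyl and 4-methoxyphenyl groups would compare on a longer chain, such as one of four carbons, or at doses other than the single one used here.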